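The compounds below may be only part of what the source reports. "The series", "measured", "known", "first", "only" and "open" are said of these compounds alone.

Compound 1 `CCCNC(=O)/C=C1\CCc2ccc(F)cc21`: in a functional assay on the whole organism with Mus musculus as the target (a higher number here means that more compound is needed for the effect, a lower number that less compound is needed), compound 1 reaches only the limit > 100 mg/kg.
Compound 2 `NC(=O)/C=C1\CCc2ccc(Br)cc21`: in this assay compound 2 gives 96 mg/kg.

Compound 1 therefore has no number of its own in this assay; what is known is the limit of > 100 mg/kg in this assay, at which 1 of the 2 values shown sits, so the dose needed for compound 1 lies somewhere beyond the range the assay could measure. Compound 2 carries a bromine on the shared core and a primary amide, and its value falls close to that same edge. Among the measured compounds shown here, no pair among the measured compounds differs in just one place, so no measured step is available to guide what follows.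

Compound 3 `O=C(/C=C1\CCc2ccc(F)cc21)NC1CCC1` has not been measured yet. It keeps the fluorine-bearing core and the amide of compound 1, and differs from it only at the amide nitrogen: cyclobutyl in place of propyl on an amide-type nitrogen. Swapping a short open chain for a small ring of the same kind of atoms, with no change in donors, acceptors or charge, is a modest alteration, and I expect the step that the limit leaves unreadable from compound 1 to compound 3 to be small, with no reliable direction beyond the scatter. For compound 3 in this assay I estimate 120 mg/kg, within a range from 40 mg/kg to 300 mg/kg, and a real chance that the assay again reports only a limit.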

Compound 3, dose for half-maximal effect: > 100 mg/kg
Compound 3: no number, only a limit (the forecaster's own chance of this, stated with the estimate: 60%); the middle value is on the limit's open side.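

Compound 3, like compound 1, ends at a limit in this assay, so the step between these two compounds cannot be read: the limit of > 100 mg/kg in this assay, at which 2 of the 3 values shown sit.

The compounds shown leave open how much of compound 1 or compound 3 the effect actually needs, and whether cyclobutyl in place of propyl on an amide-type nitrogen changes that amount at all.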